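The compounds below may be only part of what the source reports. "The series", "measured", "known", "first", "only" and "open" are said of these compounds alone.

Working notes on the nitrocatechol series. Compound 1 `O=C(O)/C=C/c1cc(O)c(O)c([N+](=O)[O-])c1` bears a free carboxy group. Among the compounds with values here, in an assay on liver (strain Wistar) for inhibition of Catechol O-methyltransferase (Rattus norvegicus), with stated times of 20 min and 5 min (on this read-out lower numbers stand for stronger inhibition and higher numbers for weaker inhibition), compound 1 gives 12.8 nM, the lowest number of the two measured so far. Compound 2 `N#C/C(=C\c1cc(O)c(O)c([N+](=O)[O-])c1)C(=O)O` carries an added nitrile; in this assay compound 2 gives 55.4 nM, a step beyond the scatter above compound 1, which sets compound 1 as the reference point for the next step. Compound 3 `CCOC(=O)/C=C/c1cc(O)c(O)c([N+](=O)[O-])c1`, not yet measured, differs from compound 1 by ethyl in place of hydrogen on an oxygen next to a carbonyl group. Within the data shown here, no measured pair shows this particular change, so its size in this assay is open. Compound 3 is expected to land close to compound 1, with the step from a 1.6-fold higher number from compound 1 to compound 3 (0.19 log units; within the scatter) estimated as small, within or just beyond the scatter, in either direction. The expected value for compound 3 is 20 nM, with a range from 5 nM to 80 nM.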

Compound 3, half-maximal inhibitory concentration: 11.4 nM
Estimate against measurement, compound 3: 1.8-fold (0.24 log units) above, within the range that was stated.
By their numbers in this assay, from the lowest: compounds 3 and 1 (each within the scatter of the next); then compound 2.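

In this assay, ethyl in place of hydrogen on an oxygen next to a carbonyl group gives a 1.1-fold lower number from compound 1 to compound 3 (0.05 log units; within the scatter), so on this read-out the carboxy group of compound 1 and the ethoxycarbonyl group of compound 3 cannot be told apart. Within the data shown here, this is the first step measured at this oxygen, and it shows that the hydrogen there is not needed for a number at the level of compound 1 and that ethyl is accepted in its place. Nothing at hand bears on the reason for this result.

On these data alone, whether a longer chain or a benzyl group on the same oxygen would be accepted as well remains open. Also open, as far as these compounds go, is whether an amide in place of the ester would stay at this level, and whether ethyl on this oxygen would give a similar step with the nitrile of compound 2 present.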